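Solubility notes on a fused diaminonitrile series

The source may hold more compounds than are shown below. What is called first, only, known or untested is meant among the compounds shown, and "the series" means these compounds.

Measured so far in a physicochemical assay for solubility, in phosphate buffer, with a stated time of 18 h; on this read-out lower numbers stand for lower solubility and higher numbers for higher solubility:
compound 1, `N#Cc1c(N)nc2nc(C3CCCC3)ncc2c1N`: 89000 nM
compound 2, `CC(C)(C)c1nc(CCCCC#N)c2c(N)c(C#N)c(N)nc2n1`: 16000 nM

Two compounds share the core and carry a different group at one ring carbon. In this assay compound 1 gives 89000 nM, while compound 2 gives 16000 nM. Among the measured compounds shown here, compound 2 stands lowest of the two numbers; its only neighbour, compound 1, sits higher by a gap that is beyond the scatter. For the measured compounds named here, the two differ in more than one place, so no single step is computed for them and only the two values themselves can be read.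

Compound 3, `CC(C)(C)c1nc(-c2ncco2)c2c(N)c(C#N)c(N)nc2n1`, has not yet been run in this assay. Relative to compound 2 the change is 1,3-oxazol-2-yl in place of 4-cyanobutyl on an aromatic carbon. The tert-butyl group and the diaminonitrile part of the core are kept.

Going by the values given here, no measured pair isolates such a change, so the step from compound 2 to compound 3 in this assay is expected to stay within the scatter, a 1.3-fold lower number from compound 2 to compound 3 (0.12 log units; within the scatter). Compound 3 is therefore estimated at 12000 nM because compound 2 gives 16000 nM, with a range from 4000 nM to 40000 nM.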

Compound 3, solubility: 50000 nM
Compound 3: middle estimate off by 4.2-fold (0.62 log units), on the low side, outside the stated range (above it).
By their numbers in this assay, from the lowest: compound 2; then compounds 3 and 1 (each within the scatter of the next).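

In this assay, among the compounds shown here, 1,3-oxazol-2-yl in place of 4-cyanobutyl on the aromatic carbon meta to the tert-butyl group gives a 3.1-fold higher number from compound 2 to compound 3 (0.49 log units; beyond the scatter), the first step that can be read for a change in one place. With the tert-butyl group and the diaminonitrile part of the core held constant, this read-out responds to the group at this position, and the step lies beyond the scatter, though it is modest in size. Nothing at hand bears on what lies behind this step, and it stands as an observation on a single pair.

The compounds shown leave open whether the step follows from the arrival of the five-membered aromatic ring or from the departure of the chain, a question that a phenyl ring, a primary amine or a plain butyl chain on the same carbon would help to separate. Also open, from the compounds shown here alone, is whether the same change gives a step of similar size when another group replaces the tert-butyl group.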